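The source may report more compounds than this note shows. Statements on the series, on what has been measured and on what is new or still open speak of the compounds shown alone.

Compound 2 `Fc1ccc(CSc2nnc(-c3ccncc3)n2-c2ccccc2)c(F)c1` gives 11400 nM in a functional assay on HCT-116 cells (Homo sapiens) for inhibition, read by MTT assay, with a stated time of 48 h; on this read-out lower numbers stand for stronger inhibition and higher numbers for weaker inhibition. Compound 1 `Brc1ccc(CSc2nnc(-c3ccncc3)n2-c2ccccc2)cc1` gives 11100 nM in this assay, and the two numbers lie within the scatter of each other. Compound 3 `O=[N+]([O-])c1ccccc1CSc1nnc(-c2ccncc2)n1-c1ccccc1` differs from compound 2 by 2-nitrophenyl in place of 2,4-difluorophenyl on a saturated chain carbon bound to a sulfur. Among the compounds with values here, the single measured step that bears on this change is a 1.0-fold higher number from compound 1 to compound 2 (0.01 log units; within the scatter), an exchange of one six-membered aromatic ring of carbon only for another at the same place, which stayed within the scatter. A step of a 1.1-fold higher number from compound 2 to compound 3 (0.02 log units; within the scatter) is therefore expected, with nothing beyond the scatter. For compound 3 the estimated value is 12000 nM, with a range from 5000 nM to 30000 nM.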

Compound 3, half-maximal inhibitory concentration: > 50000 nM
Compound 3 was reported as a limit; the forecaster's own chance of this, stated with the estimate: 5%; middle value at least 4.1-fold (0.61 log units) from the limit.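

The ring on the saturated chain carbon bound to a sulfur is not freely exchangeable, although the earlier pair suggested it might be. In this assay, 2-nitrophenyl in place of 2,4-difluorophenyl gives an at least 4.3-fold higher number from compound 2 to compound 3 (0.64 log units; beyond the scatter), and 2-nitrophenyl in place of 4-bromophenyl gives an at least 4.5-fold higher number from compound 1 to compound 3 (0.65 log units; beyond the scatter). The reading for compound 3 is a limit, not a number: the limit of > 50000 nM in this assay, at which 1 of the 3 values shown sits.

The compounds shown therefore leave open how much weaker compound 3 truly is, and why the 2-nitrophenyl ring behaves differently. They also leave open how a phenyl ring carrying an amine or a carboxylic acid would behave here.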